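Ether and ester variants at the core oxygen

The source may report more compounds than this note shows. Statements on the series, on what has been measured and on what is new or still open speak of the compounds shown alone.

Compound 2 `Cc1nn(-c2ncnc3nc[nH]c23)c2c1C(OC(=O)c1ccc(F)cc1)CC(=O)N2` gives 4 nM in a functional assay on HEK293 cells for agonist activity at G-protein coupled receptor 39 (Homo sapiens), read by scintillation proximity assay and inositol phosphate accumulation, with a stated time of 75 min, in the presence of a further agent that is not named here (a higher number here means that more compound is needed for the effect, a lower number that less compound is needed), and stands level with compound 1 `Cc1nn(-c2ncnc3nc[nH]c23)c2c1C(OCc1ccc(Cl)cc1Cl)CC(=O)N2`, which gives 4 nM; the step of no change at the digits printed from compound 1 to compound 2 (within the scatter) lies within the scatter. Compound 3 `COc1ccc(CCOC2CC(=O)Nc3c2c(C)nn3-c2ncnc3nc[nH]c23)cc1` differs from compound 2 by 2-(4-methoxyphenyl)ethyl in place of (4-fluorophenyl)carbonyl on an oxygen on a saturated carbon. Among the compounds with values here, the only measured step bearing on this oxygen is no change at the digits printed from compound 1 to compound 2 (within the scatter), where swapping 2,4-dichlorobenzyl for (4-fluorophenyl)carbonyl left the value unchanged, so the step of a 1.5-fold higher number from compound 2 to compound 3 (0.18 log units; within the scatter) in this assay is expected to stay within the scatter. Compound 3 is therefore estimated at 6 nM, with a range from 2 nM to 20 nM.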

Compound 3, half-maximal effective concentration: 2 nM
For compound 3 the middle estimate is 3.0-fold (0.48 log units) above the measured one; measured number inside the range.
By their numbers in this assay, from the lowest: compounds 3, 1 and 2 (each within the scatter of the next).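

In this assay the oxygen on a saturated carbon also carries 2-(4-methoxyphenyl)ethyl, a group without halogen, with a 2.0-fold lower number from compound 2 to compound 3 (0.30 log units; within the scatter) and with a 2.0-fold lower number from compound 1 to compound 3 (0.30 log units; within the scatter). The ether and ester groups shown on this oxygen thus all lie within the scatter of one another, so no order among them can be read. Nothing available accounts for this flat picture.

As far as these compounds go, whether this position also accepts an amine, a carboxylic acid or a bare hydroxyl stays open. All three groups shown carry a six-membered aromatic ring, so how much that ring contributes remains unknown.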